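A few compounds are considered here, and "the series" means these few. Any claim that something is new, unique, unknown or untested is made for them only; others in the source may bear on it.

Compound 1 `Cc1ccc(S(=O)(=O)/C(=C/c2sccc2C)C(=O)c2ccc(Cl)cc2)cc1` is the starting point, and it is compared here with two relatives that share its core. In a functional assay on DU-145 cells (Homo sapiens) for inhibition, read by trypan blue exclusion, with a stated time of 96 h (on this read-out lower numbers stand for stronger inhibition of growth and higher numbers for weaker inhibition of growth), compound 1 gives 10000 nM, the highest number of the three. Compound 2 `Cc1ccc(S(=O)(=O)/C(=C/c2ccc(Cl)cc2)C(=O)c2ccc(Cl)cc2)cc1` gives 1000 nM, and compound 3 `Cc1ccc(S(=O)(=O)/C(=C/c2cc(C)ccc2C)C(=O)c2ccc(Cl)cc2)cc1` gives 1000 nM. These relatives differ from compound 1 only in the group that replaces 3-methylthiophen-2-yl on a double-bonded chain carbon. The 4-chlorophenyl swap gives a 10-fold lower number from compound 1 to compound 2 (1.00 log units; beyond the scatter), and the 2,5-dimethylphenyl swap gives a 10-fold lower number from compound 1 to compound 3 (1.00 log units; beyond the scatter). Between the two replacements there is no change at the digits printed from compound 2 to compound 3 (within the scatter).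

Compound 4 `Cc1ccsc1/C=C(\C(=O)c1ccc(Cl)cc1)S(=O)(=O)Cc1ccc(Cl)cc1` keeps the 3-methylthiophen-2-yl group and changes a different place: 4-chlorobenzyl in place of 4-methylphenyl on a sulfonyl sulfur. Put simply, 4-chlorobenzyl stands in place of 4-methylphenyl on a sulfonyl sulfur. Among the measured compounds shown here, no measured step touches that sulfur, so the data offer no direct guide. The steps above show only how far numbers have moved in this small set, as in a 10-fold lower number from compound 1 to compound 2 (1.00 log units; beyond the scatter). With compound 1 at the top at 10000 nM, a smaller move towards a lower number seems a cautious expectation, and no real change remains possible. The expected change is a 2.5-fold lower number from compound 1 to compound 4 (0.40 log units; beyond the scatter). For compound 4 the estimated value is 4000 nM, within an expected range of 800 nM to 15000 nM.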

Compound 4, concentration for 50% growth inhibition: 25000 nM
The estimate for compound 4 lay 6.3-fold (0.80 log units) below the measured number; the whole stated range lies below it.
By their numbers in this assay, from the lowest: compounds 2 and 3 (each within the scatter of the next); then compound 1; then compound 4.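

In this assay, among the compounds shown here, the first measured change on the sulfonyl sulfur, 4-chlorobenzyl in place of 4-methylphenyl, gives a 2.5-fold higher number from compound 1 to compound 4 (0.40 log units; beyond the scatter) and so means weaker inhibition of growth, whereas both earlier swaps, made at the double-bonded chain carbon, gave lower numbers. This position therefore affects the read-out too, and here a change moves the number upwards even though the entering and leaving groups each hold one six-membered aromatic ring of carbon only and neither has a hydrogen-bond donor or acceptor. Nothing measured for these compounds accounts for the rise.

The new group also differs from the old one in two ways at once, as it carries chlorine in place of methyl and is a benzyl rather than a phenyl group, so this single step cannot show which difference matters; 4-methylbenzyl or unsubstituted benzyl on the sulfonyl sulfur would separate the two. As far as these compounds go, it also remains open whether 4-chlorobenzyl would raise the number in the same way when paired with the 4-chlorophenyl group of compound 2 or the 2,5-dimethylphenyl group of compound 3.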